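This account rests on a few compounds, and the source may have more. Where it says the series, first, only, none or still open, it means among the compounds named here.

The measured compounds:

Compound 1, `Cc1cccc(Cn2cc(COc3ccc4c(=O)ccoc4c3)nn2)c1`: in an ADME assay on L02 cells (Homo sapiens) for cytotoxicity, read by MTT assay, with a stated time of 48 h (on this read-out lower numbers stand for stronger inhibition and higher numbers for weaker inhibition), compound 1 gives > 300000 nM, which is a limit of the assay rather than a number.
Compound 2, `O=c1ccoc2cc(OCc3cn(Cc4ccc([N+](=O)[O-])cc4)nn3)ccc12`: in this assay compound 2 gives > 300000 nM, again a limit and not a number.
Compound 3, `O=c1ccoc2cc(OCc3cn(Cc4ccccc4Cl)nn3)ccc12`: in this assay compound 3 gives > 300000 nM, also a limit.

Compound 2 therefore stands where every measured compound stands, at the limit of > 300000 nM in this assay, at which 3 of the 3 values shown sit. Compound 4, `O=c1ccoc2cc(OCc3cn(Cc4ccc(Cl)cc4)nn3)ccc12`, has not yet been measured; it differs from compound 2 by chloro in place of nitro on an aromatic carbon. Three measured steps could speak to this change, but each of them runs between two limits: a step that the two limits leave unreadable from compound 1 to compound 2, a step that the two limits leave unreadable from compound 2 to compound 3 and a step that the two limits leave unreadable from compound 1 to compound 3. None of them can be read in size or direction, so they give no expectation of a step beyond the usual scatter in either direction. Within the data shown here, the only guide is that all three measured compounds sit at the same limit.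

For compound 4 the estimated value in this assay is 400000 nM, with a range from 150000 nM to 1500000 nM, and most likely the assay will again report only a limit. The step from compound 2 expected by this estimate is a step that the limit leaves unreadable from compound 2 to compound 4.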

Compound 4, half-maximal inhibitory concentration: > 300000 nM
Compound 4: only a limit was reported (the forecaster's own chance of this, stated with the estimate: 85%); the middle value is on the limit's open side.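

In this assay compound 4 gives > 300000 nM, which is a limit and not a number. Among these compounds, no step between compound 4 and compound 1, compound 2 or compound 3 can be read. The compounds shown leave open whether these changes on the phenyl ring alter the true values at all.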